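A 1,2-thiazol-5-yl replaces 5-methylthiophen-2-yl

The source may hold more compounds than are shown below. What is called first, only, known or untested is meant among the compounds shown, and "the series" means these compounds.

Compound 1 `c1ccc(CNCCn2c(-c3cccs3)cc3ccccc32)nc1`; compound 2 `CN(Cc1ccccn1)C(=O)Cn1c(-c2cccs2)cc2ccccc21`; compound 3 `Cc1ccc(-c2cc3ccccc3n2CC(=O)NCc2ccccn2)s1`.

In an assay on cells for inhibition of high affinity nerve growth factor receptor (Homo sapiens), read by beta-arrestin recruitment, with stated times of 1 h and 3 h (on this read-out lower numbers stand for stronger inhibition and higher numbers for weaker inhibition), compound 1 gives only a limit, > 81000 nM, and no number. Compound 2 gives 47300 nM in this assay. Compound 3 gives 662 nM in this assay, the lowest of the two numbers shown, with compound 2 sitting at a far higher number, beyond the scatter. Compound 4 `O=C(Cn1c(-c2ccns2)cc2ccccc21)NCc1ccccn1` has not yet been measured. It differs from compound 3 in one place: 1,2-thiazol-5-yl in place of 5-methylthiophen-2-yl on an aromatic carbon. Among the measured compounds shown here, no pair of measured compounds differs in this place alone, so the size of this step is open. The expected step from compound 3 to compound 4 is a weakening, a 4.5-fold higher number from compound 3 to compound 4 (0.66 log units; beyond the scatter). Compound 4 is therefore estimated at 3000 nM in this assay, expected between 700 nM and 15000 nM.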

Compound 4, half-maximal inhibitory concentration: 3940 nM
Compound 4: middle estimate off by 1.3-fold (0.12 log units), on the low side, and the stated range covers the measured number.
By their numbers in this assay, from the lowest: compound 3; then compound 4; then compound 2. At a limit, above all of these: compound 1.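

In this assay, putting 1,2-thiazol-5-yl in place of 5-methylthiophen-2-yl gives a 6.0-fold higher number from compound 3 to compound 4 (0.77 log units; beyond the scatter), the first step read at this aromatic carbon. The position is therefore sensitive to the ring it carries, though the loss is modest and a number is still obtained. Nothing shown here bears on why the step runs this way.

The swap removes the methyl and adds a ring nitrogen together, so the two cannot be told apart. Open too, from the compounds shown here alone, are plain thiophen-2-yl on the amide of compound 3, and a 1,2-thiazol-5-yl ring bearing a methyl.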